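Nitro to Methoxycarbonyl on the Shared Core

The compounds below may be only part of what the source reports. "The series", "measured", "known", "first", "only" and "open" are said of these compounds alone.

For the measured compounds named here, compound 2 `Cc1cc(NC(=O)Cn2cc(-c3ccc([N+](=O)[O-])cc3)nn2)no1` stands lowest of the two numbers so far in a functional assay on BMDM cells (Mus musculus, strain C57BL/6) for inhibition, with a stated time of 2 days (on this read-out lower numbers stand for stronger inhibition and higher numbers for weaker inhibition), where compound 2 gives 1220 nM. Its nearest neighbour is compound 1 `Cc1cc(NC(=O)Cn2cc(-c3ccc(C#N)cc3)nn2)no1`, which in this assay gives 9320 nM; the step between them, a 7.6-fold lower number from compound 1 to compound 2 (0.88 log units; beyond the scatter), is the only one measured. Compound 3 `COC(=O)c1ccc(-c2cn(CC(=O)Nc3cc(C)on3)nn2)cc1` carries the change (methoxycarbonyl in place of nitro on an aromatic carbon), on an aromatic carbon of a six-membered aromatic ring of carbon only, para to a large group. Going by the values given here, the one measured step bears on it because a 7.6-fold lower number from compound 1 to compound 2 (0.88 log units; beyond the scatter) altered the same position, yet that single step cannot say how methoxycarbonyl compares with nitro. Given that compound 1 gave 9320 nM and compound 2 gave 1220 nM, compound 3 is expected to fall between the two, as a step of a 3.3-fold higher number from compound 2 to compound 3 (0.52 log units; beyond the scatter). The estimate for compound 3 is therefore 4000 nM, with a range from 1200 nM to 13000 nM.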

Compound 3, half-maximal inhibitory concentration: > 30000 nM
Compound 3 ended at the assay's limit; the forecaster's own chance of this, stated with the estimate: 10%; at least 7.5-fold (0.87 log units) between middle value and limit.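

With methoxycarbonyl on this aromatic carbon, para to a large group, the position shows a much larger sensitivity than the earlier pair revealed, with an at least 24-fold higher number from compound 2 to compound 3 (1.39 log units; beyond the scatter) in this assay, even though nitro and methoxycarbonyl have the same counts of hydrogen-bond donors and acceptors. The new group also falls outside the range set by the two earlier groups, with an at least 3.2-fold higher number from compound 1 to compound 3 (0.50 log units; beyond the scatter), so the order of cyano and nitro gave no guide to this change. Compound 3 stands at a limit of the assay and not at a number: the limit of > 30000 nM in this assay, at which 1 of the 3 values shown sits.

On these data alone, how far compound 3 lies past that limit stays open, and with it the full size of both steps. Also open, as far as these compounds go, is whether an amine or a carboxylic acid on the same aromatic carbon would give a number close to that of compound 2 or also reach the limit.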